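The source may hold more compounds than are shown below. What is called first, only, known or untested is meant among the compounds shown, and "the series" means these compounds.

Measured so far in a functional assay on T47D cells (Homo sapiens) for cytotoxicity, read by CCK-8 assay; on this read-out lower numbers stand for stronger inhibition and higher numbers for weaker inhibition:

Compound 1, `Oc1ccccc1-c1cc(-c2cccs2)cc(-c2ccccc2O)n1`, a limit only: compound 1 gives > 50000 nM.
Compound 2, `Oc1cccc(-c2cc(-c3cccs3)cc(-c3ccccc3O)n2)c1`, a limit only: compound 2 gives > 50000 nM.
Compound 3, `Oc1cccc(-c2cc(-c3ccsc3)cc(-c3ccccc3O)n2)c1`, a limit only: compound 3 gives > 50000 nM.

The change 3-hydroxyphenyl in place of 2-hydroxyphenyl on an aromatic carbon leaves the step from compound 1 to compound 2 unreadable: a step that the two limits leave unreadable from compound 1 to compound 2, because of the limit of > 50000 nM in this assay, at which 3 of the 3 values shown sit. The change from compound 2 to compound 3 is likewise unreadable: a step that the two limits leave unreadable from compound 2 to compound 3.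

Compound 4, `Oc1cccc(-c2cc(-c3ccsc3)cc(-c3cccc(O)c3)n2)c1`, carries the same kind of change as compound 2 did, (3-hydroxyphenyl in place of 2-hydroxyphenyl on an aromatic carbon), but here the place is meta to a 3-hydroxyphenyl group and meta to a thiophen-3-yl group, where in the earlier case it was meta to a 2-hydroxyphenyl group and meta to a thiophen-2-yl group. The difference between the cores of compound 1 and compound 3 is not broken down here.

Among the measured compounds shown here, no measured step in this assay is readable, so the expectation for compound 4 rests only on the limit shared by compound 1, compound 2 and compound 3. The step from compound 3 to compound 4 is estimated as a step that the limit leaves unreadable from compound 3 to compound 4. Compound 4 is therefore expected to give roughly 60000 nM, most likely again as a limit, within 25000 nM to 200000 nM.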

Compound 4, half-maximal inhibitory concentration: 1510 nM
Beside the measured number, compound 4's estimate is 40-fold (1.60 log units) above it, and the stated range ends above it.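

In this assay, among the compounds shown here, putting 3-hydroxyphenyl in place of 2-hydroxyphenyl gives an at least 33-fold lower number from compound 3 to compound 4 (1.51 log units; beyond the scatter), and compound 4 is the only one of the four compounds with no 2-hydroxyphenyl group. The other steps cannot be read, including the same change on the core of compound 1, because both ends of each sit at a limit: the limit of > 50000 nM in this assay, at which 3 of the 4 values shown sit. This shows a large gain for the change on the thiophen-3-yl core only, and it does not show that the change carries over to the thiophen-2-yl core.

From the compounds shown here alone, it remains open whether a thiophen-2-yl analogue with two 3-hydroxyphenyl groups would match compound 4. Also open, going by these compounds, is whether an amine or a carboxylic acid could stand in place of the hydroxyl groups.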